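This account rests on a few compounds, and the source may have more. Where it says the series, first, only, none or still open, it means among the compounds named here.

Compound 1 `CCC(=O)N1CC2CC(C1)N2` carries an ethyl group on its carbonyl carbon. In an assay on SH-EP1 cells for agonist activity at Neuronal acetylcholine receptor; alpha4/beta2 (Homo sapiens), read by FLIPR and calcium flux (on this read-out higher numbers stand for larger maximal responses and lower numbers for smaller maximal responses), compound 1 gives 110%. Compound 2 `O=C([C@@H]1C[C@@H]1F)N1CC2CC(C1)N2` has a 2-fluorocyclopropyl in place of that ethyl. In this assay compound 2 gives 110%, and the step of no change at the digits printed from compound 1 to compound 2 (within the scatter) shows that swapping a small chain for a small ring left the maximal response where it was. So compound 2 stands level with compound 1 on the numbers seen so far.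

Compound 3 `C[C@@H]1C[C@H]1C(=O)N1CC2CC(C1)N2` differs from compound 2 in one place: 2-methylcyclopropyl in place of 2-fluorocyclopropyl on a carbonyl carbon. Among the compounds with values here, the only measured step that bears on this change is the one from compound 1 to compound 2, which was flat, and it involved the same position on the carbonyl carbon. A step of no change at the digits printed from compound 2 to compound 3 (within the scatter) is therefore expected, meaning none beyond the scatter. For compound 3 the value in this assay is estimated at 110%, with a range from 95% to 125%.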

Compound 3, largest response reached (Emax), in percent of the reference or control that the assay uses: 110%
Estimate against measurement, compound 3: no gap at the digits printed; measured number inside the range.
By their numbers in this assay, from the lowest: compounds 1, 2 and 3 (each within the scatter of the next).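

On a carbonyl carbon whose other neighbours are an amide-type nitrogen in a ring, putting 2-methylcyclopropyl in place of 2-fluorocyclopropyl gives no change at the digits printed from compound 2 to compound 3 (within the scatter) in this assay, so exchanging the fluorine for a carbon on the small ring leaves the maximal response as it was. The comparison with the ethyl group reads the same, with no change at the digits printed from compound 1 to compound 3 (within the scatter), so the flat first step was not peculiar to the fluorinated ring. No measured evidence explains why these groups read alike.

The compounds shown leave open whether this flat picture would hold for a longer chain, a phenyl ring or an amine at this place. They also leave open how much of each compound is needed to reach that response, which a maximal response alone cannot tell.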